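Swapping a Nitrile Chain End for a Hydroxamic Acid

The compounds below may be only part of what the source reports. "The series", "measured", "known", "first", "only" and "open" are said of these compounds alone.

Of the compounds shown here, three sharing one core have been tested in an assay on isolated protein for binding affinity to leukotriene B4 receptor 1 (Homo sapiens), tested at 1 uM; on this read-out higher numbers stand for more inhibition at the one concentration tested (going by the name of the read-out) and lower numbers for less inhibition. Compound 1 `CCCCCCc1cc(C(C)=O)c(O)cc1OCCCCC#N` gives 13%. Compound 2 `C=CCc1cc(C(C)=O)c(O)cc1OCCCCCCCCCCC#N` gives 14%. Compound 3 `CCc1cc(C(C)=O)c(O)cc1OCCCCCCCC(C)(C)C#N` gives 29%. Among these three numbers compound 2 stands second highest; its nearest neighbour is compound 1, whose number lies within the scatter of repeated measurements, while compound 3 lies beyond the scatter above it. No pair of these compounds differs in only one place, so the numbers give no isolated step to lean on.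

Compound 4 `C=CCc1cc(C(C)=O)c(O)cc1OCCCCCC(=O)NO` is not yet measured. It is reached from compound 2 by one change: hydroxycarbamoyl in place of 5-cyanopentyl on a saturated chain carbon, five bonds along the chain from an oxygen on an aromatic ring. The chain that leaves carries a nitrile at its end; the group that enters is shorter and brings two hydrogen-bond donors where there were none.

Among the measured compounds shown here, with no measured step of this kind among the three compounds, the expected change from compound 2 to compound 4 in this assay is a number 1 percentage points higher from compound 2 to compound 4 (within the scatter), that is, no move beyond the scatter in either direction, though with wide uncertainty. Compound 4 is therefore estimated to give 15% in this assay, within a range from 0% to 45%.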

Compound 4, a percentage reported as inhibition, at one concentration (the size of the read-out at that concentration, not a potency): 28%
The estimate for compound 4 lay 13 percentage points below the measured number; measured number inside the range.
By their numbers in this assay, from the lowest: compounds 1 and 2 (each within the scatter of the next); then compounds 4 and 3 (each within the scatter of the next).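

In this assay, hydroxycarbamoyl in place of 5-cyanopentyl, on a saturated chain carbon five bonds along the chain from an oxygen on an aromatic ring, gives a number 14 percentage points higher from compound 2 to compound 4 (beyond the scatter). This is the first change in one place among these compounds, and it shows that the read-out responds to what sits at this spot: a group with fewer heavy atoms and with hydrogen-bond donors does not lose inhibition here, but gains it. Nothing measured explains the gain.

The swap shortens the chain and replaces the nitrile end in a single step, so the compounds shown cannot say which of the two produced the gain. A carboxylic acid on the same short chain, or a hydroxamic acid on a longer chain, would pull these two changes apart.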